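From Methyl to Phenyl on the Carboxylated Side Chain

This account rests on a few compounds, and the source may have more. Where it says the series, first, only, none or still open, it means among the compounds named here.

In a functional assay on K562 cells (Homo sapiens) for cytotoxicity, read by trypan blue exclusion, with a stated time of 96 h (a higher number here means a weaker inhibitor, a lower number a stronger inhibitor), compound 1 `COc1cc(OC)c(/C=C/S(=O)(=O)Nc2ccc(OC)c(N)c2)c(OC)c1` gives 3 nM, and compound 2 `COc1cc(OC)c(/C=C/S(=O)(=O)Nc2ccc(OC)c(NC(C)C(=O)O)c2)c(OC)c1` gives 8 nM, the higher of the two numbers. Within the data shown here, the one measured step, a 2.7-fold higher number from compound 1 to compound 2 (0.43 log units; beyond the scatter), is modest and lies beyond the scatter. It places 1-carboxyethyl in place of hydrogen on a nitrogen on an aromatic ring. Compound 3 `COc1cc(OC)c(/C=C/S(=O)(=O)Nc2ccc(OC)c(NC(C(=O)O)c3ccccc3)c2)c(OC)c1` keeps the shared core and alters that same group: phenyl in place of methyl on a saturated chain carbon bound to a carbonyl carbon and a nitrogen on an aromatic ring. This is phenyl in place of methyl on a saturated chain carbon bound to a carbonyl carbon and a nitrogen on an aromatic ring. Among the measured compounds shown here, no measured step makes this exchange, so the evidence is thin. Only the modest size of a 2.7-fold higher number from compound 1 to compound 2 (0.43 log units; beyond the scatter) offers a guide, and a similarly modest rise in the number is expected in this assay. The expected change is a 1.9-fold higher number from compound 2 to compound 3 (0.27 log units; within the scatter). Compound 3 is estimated at 15 nM, within an expected range of 5 nM to 60 nM.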

Compound 3, half-maximal inhibitory concentration: 300 nM
Estimate against measurement, compound 3: 20-fold (1.30 log units) below, and the stated range ends below it.
By their numbers in this assay, from the lowest: compound 1; then compound 2; then compound 3.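

In this assay, the group on the saturated chain carbon turns out to matter far more than the first step suggested: phenyl in place of methyl gives a 38-fold higher number from compound 2 to compound 3 (1.57 log units; beyond the scatter), whereas the earlier pair showed only a 2.7-fold higher number from compound 1 to compound 2 (0.43 log units; beyond the scatter). Measured against the free amine, carboxy(phenyl)methyl in place of hydrogen on the nitrogen gives a 100-fold higher number from compound 1 to compound 3 (2.00 log units; beyond the scatter), so a substituent on this nitrogen can carry either a modest or a large change, depending on the group it bears. Nothing available accounts for the size of this change.

From the compounds shown here alone, it remains open whether a cyclohexyl group on that chain carbon would behave as phenyl does, or whether the ring must be aromatic. Also open, going by these compounds, is how a methyl ester in place of the carboxylic acid would move the number in either side chain.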